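Swapping the Chlorophenyl Tail for a Methylthiophene

The source may hold more compounds than are shown below. What is called first, only, known or untested is meant among the compounds shown, and "the series" means these compounds.

Measured so far, in a functional assay on MCF7 cells (Homo sapiens) for cytotoxicity; a higher number here means a weaker inhibitor, a lower number a stronger inhibitor:
compound 1 `C=C/C=C\[C@H](C)[C@H](OC(N)=O)[C@@H](C)[C@H](O)[C@@H](C)C/C(C)=C\[C@H](C)[C@@H](O)[C@@H](C)/C=C\CCc1ccsc1`: 4000 nM
compound 2 `C=C/C=C\[C@H](C)[C@H](OC(N)=O)[C@@H](C)[C@H](O)[C@@H](C)C/C(C)=C\[C@H](C)[C@@H](O)[C@@H](C)/C=C\CCc1cccc(Cl)c1`: 650 nM
compound 3 `C=C/C=C\[C@H](C)[C@H](OC(N)=O)[C@@H](C)[C@H](O)[C@@H](C)C/C(C)=C\[C@H](C)[C@@H](O)[C@@H](C)/C=C\CCc1cccc(F)c1`: 500 nM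

Compound 2 holds the second highest of the three numbers. Its nearest neighbour is compound 3, separated by a 1.3-fold lower number from compound 2 to compound 3 (0.11 log units; within the scatter), a gap within the scatter; its furthest is compound 1, whose number is higher by a 6.2-fold lower number from compound 1 to compound 2 (0.79 log units; beyond the scatter).

Compound 4 `C=C/C=C\[C@H](C)[C@H](OC(N)=O)[C@@H](C)[C@H](O)[C@@H](C)C/C(C)=C\[C@H](C)[C@@H](O)[C@@H](C)/C=C\CCc1sccc1C` differs from compound 2 in one place: 3-methylthiophen-2-yl in place of 3-chlorophenyl on a saturated chain carbon, two bonds along the chain from a double-bonded chain carbon. Among the measured compounds shown here, two measured steps bear on this change. Going from a thiophene ring to a halogen-bearing phenyl ring gave a 6.2-fold lower number from compound 1 to compound 2 (0.79 log units; beyond the scatter) and an 8.0-fold lower number from compound 1 to compound 3 (0.90 log units; beyond the scatter), both beyond the scatter and both lowering the number. The step to compound 4 runs the other way, from a phenyl ring back to a thiophene ring, so the number is expected to rise. For the measured compounds named here, the added methyl group has no measured precedent here, so the expected step is taken as somewhat smaller than those two, namely a 3.8-fold higher number from compound 2 to compound 4 (0.59 log units; beyond the scatter). Compound 4 is therefore estimated at 2500 nM, with a range from 1000 nM to 6000 nM.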

Compound 4, half-maximal inhibitory concentration: 620 nM
Beside the measured number, compound 4's estimate is 4.0-fold (0.61 log units) above it, outside the stated range (below it).
By their numbers in this assay, from the lowest: compounds 3, 4 and 2 (each within the scatter of the next); then compound 1.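

In this assay, a thiophene ring on this saturated chain carbon does not by itself bring the higher number: the data give a 1.0-fold lower number from compound 2 to compound 4 (0.02 log units; within the scatter) and a 1.2-fold higher number from compound 3 to compound 4 (0.09 log units; within the scatter) so 3-methylthiophen-2-yl matches both halogen-bearing phenyl groups, while they give a 6.5-fold lower number from compound 1 to compound 4 (0.81 log units; beyond the scatter) as a clear separation between the two thiophene groups. The split between phenyl and thiophene suggested by compounds 1, 2 and 3 therefore does not hold as a general pattern, and compound 4 is the one that goes against it, leaving compound 1 alone with the high number. No measurement here explains this result.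

The thiophene groups of compound 1 and compound 4 differ in more than the methyl, so the compounds shown leave open what a thiophen-2-yl group without the methyl would give. Also open, from the compounds shown here alone, is how an unsubstituted phenyl or a pyridine ring would behave at this place.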